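From 4-methoxyphenyl to 6-methoxypyridin-3-yl: working notes

The source may report more compounds than this note shows. Statements on the series, on what has been measured and on what is new or still open speak of the compounds shown alone.

Measured in an ADME assay on L02 cells (Homo sapiens) for cytotoxicity, read by MTT assay, with a stated time of 72 h; a higher number here means a weaker inhibitor, a lower number a stronger inhibitor:
- compound 1 `C/C=C/C(=O)Nc1cccc(Oc2nc(Nc3ccc(OC)cc3)nc3c2CSCC3)c1` gives > 50000 nM as a limit
- compound 2 `CCC/C=C/C(=O)Nc1cccc(Oc2nc(Nc3ccc(OC)cc3)nc3c2CSCC3)c1` gives > 50000 nM as a limit
- compound 3 `COc1ccc(Nc2nc3c(c(Oc4cccc(NC(=O)C=C(C)C)c4)n2)CSCC3)cc1` gives > 50000 nM as a limit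

Compound 3 stands at the limit > 50000 nM and has no numeric value. The series offers only the limit of > 50000 nM in this assay, at which 3 of the 3 values shown sit, as a guide. The change to compound 4 `COc1ccc(Nc2nc3c(c(Oc4cccc(NC(=O)C=C(C)C)c4)n2)CSCC3)cn1` is 6-methoxypyridin-3-yl in place of 4-methoxyphenyl on a nitrogen on an aromatic ring, so 6-methoxypyridin-3-yl replaces 4-methoxyphenyl on a nitrogen on an aromatic ring. Three steps are measured: a step that the two limits leave unreadable from compound 1 to compound 2, a step that the two limits leave unreadable from compound 1 to compound 3 and a step that the two limits leave unreadable from compound 2 to compound 3. All three alter the chain on the carbonyl carbon, so none gives a size for this change. In this assay, the expected a number no higher from compound 3 to compound 4 (the limit leaves the size open) is no larger than the scatter, with no expected direction. Compound 4 is estimated at 50000 nM, with an expected range of 25000 nM to 80000 nM.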

Compound 4, half-maximal inhibitory concentration: > 50000 nM
Compound 4: no number, only a limit (the forecaster's own chance of this, stated with the estimate: 80%); the middle value sits exactly at the limit.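

Compound 3 and compound 4 both give only a limit in this assay, so no step can be read between them. The compounds shown leave open whether 6-methoxypyridin-3-yl in place of 4-methoxyphenyl has any effect on this read-out.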